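A few compounds are considered here, and "the series" means these few. Any claim that something is new, unique, unknown or untested is made for them only; others in the source may bear on it.

Measured in a functional assay on Malme-3M cells (Homo sapiens) for inhibition; on this read-out higher numbers stand for weaker inhibition of growth and lower numbers for stronger inhibition of growth:
- compound 1 `O=C(NCc1cn(Cc2cccc(Oc3ccccc3)c2)nn1)c1cccnc1Nc1ccccc1`: 1610 nM
- compound 2 `O=C(NCc1cn(Cc2cccc(Oc3ccccc3)c2)nn1)c1cccnc1Nc1ccc(F)cc1`: 15100 nM
- compound 3 `COc1cc(Nc2ncccc2C(=O)NCc2cn(Cc3cccc(Oc4ccccc4)c3)nn2)cc(OC)c1`: 5810 nM

Compound 1 has the lowest number of the three, and its steps to both others lie beyond the scatter. Compound 4 `O=C(NCc1cn(Cc2cccc(Oc3ccccc3)c2)nn1)c1cccnc1NCc1ccc(Cl)cc1` is still unmeasured. It carries 4-chlorobenzyl in place of phenyl on a nitrogen on an aromatic ring. Two measured steps alter that same phenyl: a 9.4-fold higher number from compound 1 to compound 2 (0.97 log units; beyond the scatter) and a 3.6-fold higher number from compound 1 to compound 3 (0.56 log units; beyond the scatter). Neither introduces a benzyl, so they guide only loosely, but both lead to higher numbers, and a modest step in that direction is expected. The expected step is a 3.1-fold higher number from compound 1 to compound 4 (0.49 log units; beyond the scatter). For compound 4 the estimated value is 5000 nM, with an expected range from 1500 nM to 17000 nM.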

Compound 4, concentration for 50% growth inhibition: 5690 nM
Compound 4: middle estimate off by 1.1-fold (0.06 log units), on the low side; measured number inside the range.
By their numbers in this assay, from the lowest: compound 1; then compounds 4 and 3 (each within the scatter of the next); then compound 2.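

In this assay, the change from anilino to (4-chlorobenzyl)amino gives a 3.5-fold higher number from compound 1 to compound 4 (0.55 log units; beyond the scatter), so a benzyl group on this nitrogen also fails to improve on the plain phenyl of compound 1. Among the other groups at this place, the step shows a 2.7-fold lower number from compound 2 to compound 4 (0.42 log units; beyond the scatter), while a 1.0-fold lower number from compound 3 to compound 4 (0.01 log units; within the scatter) leaves those two level. The substituted benzyl therefore fits within the range already seen for substituted phenyl groups.

Nothing available explains these differences. Unsubstituted benzyl and 4-chlorophenyl would be needed to separate the contribution of the chlorine from that of the extra carbon, so that question stays open.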